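The source may report more compounds than this note shows. Statements on the series, on what has been measured and on what is new or still open speak of the compounds shown alone.

In a functional assay on HT-29 cells (Homo sapiens) for cytotoxicity, read by MTT assay, with a stated time of 72 h (on this read-out lower numbers stand for stronger inhibition and higher numbers for weaker inhibition), compound 3 (`N[C@H]1CC[C@H](Nc2c(C(=O)NCc3ccc(F)cc3)nc(Br)c3cccnc23)CC1`) gives < 1000 nM, which is a limit. Compound 1 (`N[C@H]1CC[C@H](Nc2c(C(=O)NCc3ccc(F)cc3)nc(N3CCCCS3(=O)=O)c3cccnc23)CC1`) gives > 10000 nM, also a limit. Compound 2 (`Nc1cccc(Nc2c(C(=O)NCc3ccc(F)cc3)nc(Br)c3cccnc23)c1`) gives > 10000 nM, again a limit. Compound 3 therefore stands at the low end of the three values shown in this assay.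

Compound 4 (`CNCCCNc1c(C(=O)NCc2ccc(F)cc2)nc(Br)c2cccnc12`) alters the group on a nitrogen on an aromatic ring: 3-(methylamino)propyl in place of 4-aminocyclohexyl on a nitrogen on an aromatic ring. The closest evidence is an at least 10-fold lower number from compound 2 to compound 3 (1.00 log units; beyond the scatter), a change at that same place. The other measured step, an at least 10-fold lower number from compound 1 to compound 3 (1.00 log units; beyond the scatter), was made on an aromatic carbon and bears less directly. No open chain has been measured at this place.

Given an at least 10-fold lower number from compound 2 to compound 3 (1.00 log units; beyond the scatter), a modest move to a higher number is expected, namely an at least 2.5-fold higher number from compound 3 to compound 4 (0.39 log units; beyond the scatter). Compound 4 is estimated at 2500 nM, with an expected range of 500 nM to 10000 nM.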

Compound 4, half-maximal inhibitory concentration: > 10000 nM
Compound 4 was reported as a limit; the forecaster's own chance of this, stated with the estimate: 30%; middle value at least 4.0-fold (0.60 log units) from the limit.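

Putting the open chain 3-(methylamino)propyl in place of 4-aminocyclohexyl on this nitrogen gives an at least 10-fold higher number from compound 3 to compound 4 (1.00 log units; beyond the scatter) in this assay. Together with the 3-aminophenyl of compound 2, this leaves 4-aminocyclohexyl as the only group shown at this place that reads at the low end. The value of compound 4 is a limit: the limit of > 10000 nM in this assay, at which 3 of the 4 values shown sit.

The step from compound 2 to compound 4 cannot be read, as both values are limits. On these data alone, whether a piperidine or a longer chain with a primary amine at this place would match compound 3 stays open.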